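From compound 2 to compound 4: a step behind limits

This account rests on a few compounds, and the source may have more. Where it says the series, first, only, none or still open, it means among the compounds named here.

Measured so far in a functional assay on MDA-MB-231 cells (Homo sapiens) for cytotoxicity, read by MTT assay, with a stated time of 24 h (a lower number here means a stronger inhibitor, a higher number a weaker inhibitor), as follows
- compound 1 (`COc1ccc2[nH]c(-c3cc(OC)c(OC)c(OC)c3)cc2c1`) gives > 30000 nM as a limit
- compound 2 (`COc1ccc2c(c1)cc(-c1cc(OC)c(OC)c(OC)c1)n2Cc1ccccc1`) gives > 30000 nM as a limit
- compound 3 (`COc1ccc2c(c1)c(Cc1ccc(OCc3ccccc3)cc1)c(-c1cc(OC)c(OC)c(OC)c1)n2Cc1ccc(OCc2ccccc2)cc1`) gives > 30000 nM as a limit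

Compound 2 stands at > 30000 nM which is a limit and not a number. The two other values shown are limits as well. Across the series the evidence is the limit of > 30000 nM in this assay, at which 3 of the 3 values shown sit, and nothing more.

Compound 4 (`CCOCC(=O)Oc1ccc(Cn2c(-c3cc(OC)c(OC)c(OC)c3)cc3cc(OC)ccc32)cc1`) differs from compound 2 by ((ethoxymethyl)carbonyl)oxy in place of hydrogen on an aromatic carbon and so carries ((ethoxymethyl)carbonyl)oxy in place of hydrogen on an aromatic carbon, para to a large group.

Within the data shown here, the only measured step of a single change is a step that the two limits leave unreadable from compound 1 to compound 2 and it concerns another place, so it offers no size to carry over. Compound 3, with larger additions to the core of compound 1, gives no readable number either. No clear step is therefore expected in this assay and a further reading at the limit is the likeliest outcome, with a small gain in strength possible. The step expected is an at least 1.2-fold lower number from compound 2 to compound 4 (0.07 log units; that floor lies within the scatter) as an estimate only. For compound 4 the expected value is 25000 nM with an estimated range from 8000 nM to 50000 nM as a working figure.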

Compound 4, half-maximal inhibitory concentration: > 30000 nM
Compound 4: only a limit was reported; the forecaster's own chance of this, stated with the estimate: 70%; middle value at least 1.2-fold (0.07 log units) from the limit.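

In this assay compound 4 gives > 30000 nM, which is a limit and not a number. Compound 2 also stands at a limit, so the step between compound 2 and compound 4 cannot be read. The compounds shown leave open whether any change to the shared core gives a measurable value in this assay.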